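The compounds below may be only part of what the source reports. "The series", "measured", "known", "first", "only" and "open" are said of these compounds alone.

Of the compounds shown here, three that share one core have been tested so far: compound 1 `CCCCNC(=O)C1C(C(=O)O)[C@@H]2CC[C@H]1O2`, compound 2 `CCCNC(=O)C1C(C(=O)O)[C@@H]2CC[C@H]1O2` and compound 3 `C=CCNC(=O)C1C(C(=O)O)[C@@H]2CC[C@H]1O2`. In an ADME assay on BE(2)-C cells (Homo sapiens) for cytotoxicity, read by MTT assay, with a stated time of 72 h (a lower number here means a stronger inhibitor of growth, a higher number a weaker inhibitor of growth), compound 1 gives 10000 nM, compound 2 gives 10000 nM and compound 3 gives 10000 nM, so compound 2 stands level with the other two. The three steps that link them, no change at the digits printed from compound 1 to compound 2 (within the scatter), no change at the digits printed from compound 1 to compound 3 (within the scatter) and no change at the digits printed from compound 2 to compound 3 (within the scatter), show that trimming or changing the chain on the amide-type nitrogen leaves the read-out where it was.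

Compound 4 `O=C(O)CCCCCCCNC(=O)C1C(C(=O)O)[C@@H]2CC[C@H]1O2` has not been measured. It differs from compound 2 as follows: 4-carboxybutyl in place of hydrogen on a saturated chain carbon, three bonds along the chain from an amide-type nitrogen. This is a larger change than any measured step, and none of those steps adds a carboxylic acid to the chain. Within the data shown here, still, the only steps that bear on this position all stay within the scatter, so the step from compound 2 to compound 4 in this assay is expected to be about no change at the digits printed from compound 2 to compound 4 (within the scatter). Compound 4 is therefore estimated at 10000 nM, within a range from 5000 nM to 20000 nM.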

Compound 4, concentration for 50% growth inhibition: 10000 nM
Compound 4: middle estimate and measured number agree at the digits printed; the measured number falls inside the stated range.
By their numbers in this assay, from the lowest: compounds 1, 2, 3 and 4 (each within the scatter of the next).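

In this assay the chain on the amide-type nitrogen now takes a much larger addition than any earlier step made: 4-carboxybutyl in place of hydrogen gives no change at the digits printed from compound 2 to compound 4 (within the scatter) and 3-carboxypropyl in place of hydrogen, read from the butyl chain, gives no change at the digits printed from compound 1 to compound 4 (within the scatter) in the same assay. The earlier steps shown here only trimmed the chain or brought in vinyl, whereas these two also place a carboxylic acid on it, and all four compounds still stand level. No supporting measurement is available to explain this flat result.

The compounds shown leave open whether an amine or a phenyl ring on this chain would shift the read-out. The shared core stays the same throughout, so they also say nothing about changes made to it.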